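The source may hold more compounds than are shown below. What is called first, only, known or untested is meant among the compounds shown, and "the series" means these compounds.

Compound 1 `Cn1ccc2cc(-c3cc4nccc(-c5ccc(F)cc5)n4n3)ccc21`: 3520 nM
Compound 2 `COc1cc(-c2ccnc3cc(-c4ccc(C)c(C)c4)nn23)cc(OC)c1OC`: 272 nM

In a functional assay on A549 cells (Homo sapiens) for inhibition, read by CCK-8 assay, with a stated time of 48 h (on this read-out lower numbers stand for stronger inhibition and higher numbers for weaker inhibition), compound 2 gives 272 nM, the lower of the two numbers. Compound 1 gives 3520 nM. The gap between the two numbers lies beyond the scatter. Compound 3 `C=Cc1ccc(-c2cc3nccc(-c4cc(OC)c(OC)c(OC)c4)n3n2)cc1` has 4-vinylphenyl in place of 3,4-dimethylphenyl on an aromatic carbon. Among the compounds with values here, no measured pair shows this change, so the expectation rests on compound 2 at 272 nM, with no step beyond the scatter in this assay in either direction. The expected change is a 1.1-fold higher number from compound 2 to compound 3 (0.04 log units; within the scatter). For compound 3 the estimated value is 300 nM, with an expected range of 100 nM to 900 nM.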

Compound 3, half-maximal inhibitory concentration: 1030 nM
Estimate against measurement, compound 3: 3.4-fold (0.54 log units) below, outside the stated range (above it).
By their numbers in this assay, from the lowest: compound 2; then compound 3; then compound 1.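

In this assay, putting 4-vinylphenyl in place of 3,4-dimethylphenyl on this aromatic carbon gives a 3.8-fold higher number from compound 2 to compound 3 (0.58 log units; beyond the scatter), although both groups have 8 heavy atoms and one six-membered aromatic ring of carbon only. This position therefore responds to what the phenyl ring carries, not just to the presence of a ring of this size. Going by these compounds, whether an amine or a carboxylic acid on this phenyl ring would lower or raise the number remains open. No measurement shown accounts for the difference between the two groups.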